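Solubility notes: amide replacement on the shared core

The source may report more compounds than this note shows. Statements on the series, on what has been measured and on what is new or still open speak of the compounds shown alone.

Measured so far:
compound 1, `O=C(c1cccnc1)N1CCC(NS(=O)(=O)c2cc(S(=O)(=O)c3ccccc3)ccc2C(F)(F)F)CC1`, 50000 nM
compound 2, `CC(C)(C)OC(=O)N1CC[C@H](C(=O)N2CCC(NS(=O)(=O)c3cc(S(=O)(=O)c4ccccc4)ccc3C(F)(F)F)CC2)C1`, 25000 nM

Going by the values given here, in a physicochemical assay for solubility (a lower number here means a less soluble compound, a higher number a more soluble compound), compound 1 gives 50000 nM, the higher of the two numbers; the only neighbour is compound 2 at 25000 nM, and the step of a 2.0-fold lower number from compound 1 to compound 2 (0.30 log units; within the scatter) is within the scatter, so no order between them is claimed.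

Compound 3, `O=C(C1CCNCC1)N1CCC(NS(=O)(=O)c2cc(S(=O)(=O)c3ccccc3)ccc2C(F)(F)F)CC1`, is unmeasured. It differs from compound 1 as follows: piperidin-4-yl in place of pyridin-3-yl on a carbonyl carbon. The group that enters carries one hydrogen-bond donor where the group that leaves had none, and the ring is non-aromatic.

Among the compounds with values here, only the step from compound 1 to compound 2 bears on this change, and it exchanged the pyridin-3-yl for a different group, so it gives little guidance beyond showing that the carbonyl substituent can be varied without a step beyond the scatter. Compound 3 is nevertheless expected to give a higher number in this assay, a 3.0-fold higher number from compound 1 to compound 3 (0.48 log units; beyond the scatter), an estimate of 150000 nM with a range from 50000 nM to 500000 nM.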

Compound 3, solubility: 100000 nM
The estimate for compound 3 lay 1.5-fold (0.18 log units) above the measured number; the range from low to high includes it.
By their numbers in this assay, from the lowest: compounds 2, 1 and 3 (each within the scatter of the next, the first and the last beyond it).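

In this assay, piperidin-4-yl in place of pyridin-3-yl on a carbonyl carbon gives a 2.0-fold higher number from compound 1 to compound 3 (0.30 log units; within the scatter). This position therefore accepts a non-aromatic ring carrying one hydrogen-bond donor without a step that can be told from the scatter. Piperidin-4-yl in place of 1-(tert-butoxycarbonyl)pyrrolidin-3-yl gives a 4.0-fold higher number from compound 2 to compound 3 (0.60 log units; beyond the scatter), a modest step and the only one in the series so far beyond the scatter, and the data offer no explanation for either step.

The change from compound 1 to compound 3 alters ring aromaticity and donor count together, so the two remain unseparated. Also open, as far as these compounds go, is whether an open-chain amine or a carboxylic acid on the carbonyl carbon would differ from compound 1 by more than the scatter.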